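Swapping the Dimethoxyphenyl on the Thioether for Ethylphenyl

The compounds below may be only part of what the source reports. "The series", "measured", "known", "first", "only" and "open" are said of these compounds alone.

Measured compounds:
compound 1, `COc1ccc(SCc2ccc(/C=C/C(=O)Nc3ccccc3N)cc2)cc1OC` — 46.4%
compound 2, `Nc1ccccc1NC(=O)c1ccc(CSc2ccc(C(F)(F)F)cn2)cc1` — 5.34%

In a functional assay on A-375 cells (Homo sapiens) for inhibition, read by CCK-8 assay, with a stated time of 72 h, tested at 8 uM (on this read-out lower numbers stand for less inhibition of growth and higher numbers for more inhibition of growth at the one concentration tested), compound 1 gives 46.4%, the higher of the two numbers measured. Compound 2 gives 5.34%, and the gap between the two lies beyond the scatter. Within the data shown here, the two compounds differ in several places at once, so no single step between them can be read, and compound 2 only shows how far compound 1 stands above it.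

Compound 3, `CCc1ccc(SCc2ccc(/C=C/C(=O)Nc3ccccc3N)cc2)cc1`, has not yet been measured. It differs from compound 1 in one place: 4-ethylphenyl in place of 3,4-dimethoxyphenyl on a sulfur. Among the measured compounds shown here, no measured pair shows what such a swap does here, so the step of a number 6.4 percentage points lower from compound 1 to compound 3 (within the scatter) is expected to be small, with no clear direction beyond the scatter. Compound 3 is therefore estimated at 40%, within a range from 20% to 60%.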

Compound 3, percent growth inhibition at one concentration: 58.4%
Beside the measured number, compound 3's estimate is 18.4 percentage points below it, within the range that was stated.
By their numbers in this assay, from the lowest: compound 2; then compound 1; then compound 3.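

Among these compounds, the step of a number 12 percentage points higher from compound 1 to compound 3 (beyond the scatter) in this assay is the first single change that can be read in this set, and it shows that the group on the sulfur affects growth inhibition at the one concentration tested. The 3,4-dimethoxyphenyl is not required for this level of inhibition: 4-ethylphenyl, with 0 hydrogen-bond acceptors in place of 2, gives the higher number. No measurement shown here explains why the number rises.

The compounds shown leave open whether the ethyl itself matters, since no compound carries a longer chain such as butyl, or an amine or a carboxylic acid, in its place. They also leave open whether the same swap would have a similar effect on a different core, as this single pair comes from one core only.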